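A few compounds are considered here, and "the series" means these few. Any claim that something is new, unique, unknown or untested is made for them only; others in the source may bear on it.

Measured in a functional assay on MCF7 cells (Homo sapiens) for inhibition, read by CCK-8 assay, with a stated time of 48 h; a lower number here means a stronger inhibitor of growth, a higher number a weaker inhibitor of growth:
- compound 1 `COc1ccc(CNc2nc(Nc3ccc(N4CCN(C)CC4)cn3)ncc2Cl)cc1`: 17300 nM
- compound 2 `Cc1cccc(Nc2nc(Nc3ccc(N4CCN(C)CC4)cn3)ncc2Cl)c1`: 7160 nM

Compound 2, at 7160 nM, has the lower of the two numbers in this assay. Compound 3 `CC(C)c1ccc(Nc2nc(Nc3ccc(N4CCN(C)CC4)cn3)ncc2Cl)cc1` carries 4-isopropylphenyl in place of 3-methylphenyl on a nitrogen on an aromatic ring.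

Within the data shown here, only one measured step bears on this place, a 2.4-fold lower number from compound 1 to compound 2 (0.38 log units; beyond the scatter), and it is modest. Among the measured compounds shown here, no measured pair compares two phenyl groups, so the direction is uncertain, and a small further fall is expected at most.

The expected change is a 1.4-fold lower number from compound 2 to compound 3 (0.16 log units; within the scatter). For compound 3 the estimate is 5000 nM, with an expected range of 2000 nM to 13000 nM.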

Compound 3, concentration for 50% growth inhibition: 1880 nM
Compound 3: the middle estimate sits 2.7-fold (0.42 log units) above what was measured; the whole stated range lies above it.
By their numbers in this assay, from the lowest: compound 3; then compound 2; then compound 1.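

In this assay, the group on this nitrogen matters even when the phenyl ring is kept: 4-isopropylphenyl in place of 3-methylphenyl gives a 3.8-fold lower number from compound 2 to compound 3 (0.58 log units; beyond the scatter) and so changes the number more than the earlier step did. Against the 4-methoxybenzyl group, the same 4-isopropylphenyl group gives a 9.2-fold lower number from compound 1 to compound 3 (0.96 log units; beyond the scatter), the largest step among these compounds. No evidence here accounts for either step.

The compounds shown leave open whether the fall belongs to the isopropyl group itself or to where it sits on the ring. They also leave open whether a tert-butyl or dimethylamino group on that ring would lower the number further.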